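The source may report more compounds than this note shows. Statements on the series, on what has been measured and on what is new or still open speak of the compounds shown alone.

Three compounds share one core and differ only in the group carried on the thiocarbonyl carbon. In a functional assay on MGC-803 cells (Homo sapiens) for antiproliferative activity, read by CCK-8 assay, with a stated time of 72 h, tested at 8 uM (a lower number here means a weaker effect, a higher number a stronger effect of the compound at the concentration tested), compound 1 `CN(Cc1cccnc1)C(=S)SCc1ccc(C(=O)Nc2ccccc2N)cc1` gives 85.5%, compound 2 `Nc1ccccc1NC(=O)c1ccc(CSC(=S)N2CCCc3ccccc32)cc1` gives 87.5%, and compound 3 `CN(Cc1ccncc1)C(=S)SCc1ccc(C(=O)Nc2ccccc2N)cc1` gives 83.2%. Compound 3 holds the lowest of these three numbers, yet both gaps to it are within the scatter: a number 2.3 percentage points lower from compound 1 to compound 3 (within the scatter) and a number 4.3 percentage points lower from compound 2 to compound 3 (within the scatter). Compound 4 `Nc1ccccc1NC(=O)c1ccc(CSC(=S)N2CCCC2)cc1` differs from compound 3 in one place: pyrrolidin-1-yl in place of methyl((pyridin-4-yl)methyl)amino on a thiocarbonyl carbon. The earlier exchanges at this position, a number 2 percentage points higher from compound 1 to compound 2 (within the scatter) and a number 4.3 percentage points lower from compound 2 to compound 3 (within the scatter), both stayed within the scatter, so no step beyond the scatter is expected here either. For compound 4 the expected step is a number 0.8 percentage points higher from compound 3 to compound 4 (within the scatter), giving an estimated 84% with a range from 72% to 92%.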

Compound 4, a percentage reported as inhibition, at one concentration (the size of the read-out at that concentration, not a potency): 83.4%
Beside the measured number, compound 4's estimate is 0.6 percentage points above it, within the range that was stated.
By their numbers in this assay, from the lowest: compounds 3, 4, 1 and 2 (each within the scatter of the next).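

In this assay the pyrrolidin-1-yl group puts a five-membered non-aromatic ring on the thiocarbonyl carbon, yet every new step stays within the scatter: a number 0.2 percentage points higher from compound 3 to compound 4 (within the scatter), a number 4.1 percentage points lower from compound 2 to compound 4 (within the scatter) and a number 2.1 percentage points lower from compound 1 to compound 4 (within the scatter). Among these four compounds, then, an aromatic ring in this group is not needed for this read-out at the tested concentration. Nothing available explains why these groups read alike. Whether a piperidine carrying a carboxylic acid, or a long open alkyl chain, would read the same here stays open, as does whether the effects of these compounds would also read alike at other concentrations, which one concentration cannot show.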